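A few compounds are considered here, and "the series" means these few. Any claim that something is new, unique, unknown or untested is made for them only; others in the source may bear on it.

Measured compounds:
compound 1, `CCc1nc2ccc(Cl)cn2c1C(=O)NCc1ccc(-c2ccccc2Cl)cc1`: 0.648 h
compound 2, `CCc1nc2cc(Cl)ccn2c1C(=O)NCc1ccc(-c2ccc(C)cc2)cc1`: 0.423 h

In an ADME assay (liver) for metabolic stability, with Liver microsome (Homo sapiens) as the target, using microsomes (a higher number here means that the compound lasts longer, a lower number that the compound disappears faster), compound 2 stands at the lower of the two numbers, though its gap to compound 1 lies within the usual scatter of such measurements. Compound 3, `CCc1nc2cc(Cl)ccn2c1C(=O)NCc1ccc(N2CCCCCC2)cc1`, is yet to be measured; it differs from compound 2 by azepan-1-yl in place of 4-methylphenyl on an aromatic carbon. Within the data shown here, no measured pair shows a change of this kind, so nothing here indicates its effect. The expected step of a 1.2-fold lower number from compound 2 to compound 3 (0.08 log units; within the scatter) is therefore small, toward a shorter half-life if anything, and not beyond the scatter. Compound 3 is estimated at 0.35 h, with a range from 0.15 h to 0.8 h.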

Compound 3, half-life: 0.0483 h
Compound 3: middle estimate off by 7.2-fold (0.86 log units), on the high side; the whole stated range lies above it.
By their numbers in this assay, from the lowest: compound 3; then compounds 2 and 1 (each within the scatter of the next).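

In this assay, this position, on an aromatic carbon and para to a large group, is sensitive to the group it carries: azepan-1-yl in place of 4-methylphenyl gives an 8.8-fold lower number from compound 2 to compound 3 (0.94 log units; beyond the scatter). The two groups match in heavy-atom count, so that count alone does not keep the half-life unchanged. Nothing measured here accounts for the step.

From the compounds shown here alone, whether the ring nitrogen, the ring size or the non-aromatic ring sets the step remains open. Cyclohexyl, piperidin-1-yl or dimethylamino at this position would help separate these features.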